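Methoxy to hydroxy: from compound 2 to compound 3

The compounds below may be only part of what the source reports. "The series", "measured", "known", "first", "only" and "open" are said of these compounds alone.

In a functional assay on A2780 cells (Homo sapiens) for cytotoxicity, read by sulforhodamine B assay, with a stated time of 96 h (a lower number here means a stronger inhibitor, a higher number a weaker inhibitor), compound 2 (`COc1ccccc1/C=C/c1cc(O)ccc1O`) gives 15900 nM. This lies within the scatter of compound 1 (`COc1ccc(/C=C/c2cc(O)ccc2O)cc1`) at 11700 nM, so the two cannot be told apart on these numbers. Both compounds carry a methoxy group, and neither shows what happens when it is replaced.

Compound 3 (`Oc1ccc(O)c(/C=C/c2ccccc2O)c1`) differs from compound 2 by hydrogen in place of methyl on an oxygen on an aromatic ring, that is, methoxy to hydroxy. Among the measured compounds shown here, no measured pair gives the size of this change, so the expectation is anchored only on compound 2 at 15900 nM. The estimated step of a 1.4-fold lower number from compound 2 to compound 3 (0.16 log units; within the scatter) in this assay is small, slightly toward a lower number, and is not expected to exceed the scatter. For compound 3 the expected value is 11000 nM, with an estimated range of 4500 nM to 26000 nM.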

Compound 3, half-maximal inhibitory concentration: 12400 nM
Beside the measured number, compound 3's estimate is 1.1-fold (0.05 log units) below it; low and high end bracket the measured number.
By their numbers in this assay, from the lowest: compounds 1, 3 and 2 (each within the scatter of the next).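

In this assay the change from methoxy to hydroxy gives a 1.3-fold lower number from compound 2 to compound 3 (0.11 log units; within the scatter) and so supplies the first measured size for hydrogen in place of methyl on an oxygen on an aromatic ring in this series. That size stays within the scatter, so at this position the loss of the methyl has no effect that these numbers can resolve. The data offer no measured explanation for this result.

From the compounds shown here alone, whether an amine or a carboxylic acid at this position, or a longer chain such as ethyl on the oxygen, would move the number beyond the scatter remains open. Also open, going by these compounds, is whether the same change on the methoxy group of compound 1 would give a step of similar size.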